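Cyclopropylamino versus anilino on the shared pyrimidine-type core

This account rests on a few compounds, and the source may have more. Where it says the series, first, only, none or still open, it means among the compounds named here.

Measured so far in a functional assay on PC-3 cells (Homo sapiens) for inhibition, with a stated time of 72 h; on this read-out lower numbers stand for stronger inhibition and higher numbers for weaker inhibition:
- compound 1, `O=C(Nc1ccccc1)Nc1nc(NC2CC2)cc(Sc2c[nH]c3ccccc23)n1`: 17500 nM
- compound 2, `O=C(Nc1ccccc1)Nc1nc(Nc2ccccc2)cc(Sc2c[nH]c3ccccc23)n1`: 26400 nM
- compound 3, `Cc1cc(Cl)ccc1NC(=O)Nc1nc(Nc2ccccc2)cc(Sc2c[nH]c3ccccc23)n1`: 41900 nM

Compound 3 and compound 2 lie within the scatter of each other, as the step of a 1.6-fold higher number from compound 2 to compound 3 (0.20 log units; within the scatter) shows. Against compound 1 the gap of compound 3 is wider and lies beyond the scatter, as the two values of compound 1 and compound 3 show. The step of a 1.5-fold higher number from compound 1 to compound 2 (0.18 log units; within the scatter) was within the scatter as well.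

Compound 4, `Cc1cc(Cl)ccc1NC(=O)Nc1nc(NC2CC2)cc(Sc2c[nH]c3ccccc23)n1`, is not yet measured. It differs from compound 3 in one place: cyclopropyl in place of phenyl on a nitrogen on an aromatic ring. This is the same exchange that separates compound 1 from compound 2, run in the opposite direction. That step bears directly on what to expect, and it was small. The step from compound 1 to compound 2 gave a higher number, so the reverse exchange in compound 4 is expected to give a somewhat lower number than compound 3, but nothing beyond the scatter, because a 1.5-fold higher number from compound 1 to compound 2 (0.18 log units; within the scatter) stayed inside it. The step expected in this assay is therefore a 1.5-fold lower number from compound 3 to compound 4 (0.18 log units; within the scatter). Compound 4 is expected to give 28000 nM, with a range from 12000 nM to 65000 nM.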

Compound 4, half-maximal inhibitory concentration: 11100 nM
Beside the measured number, compound 4's estimate is 2.5-fold (0.40 log units) above it; measured number below the stated range.
By their numbers in this assay, from the lowest: compounds 4, 1, 2 and 3 (each within the scatter of the next, the first and the last beyond it).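

In this assay, the exchange of anilino for cyclopropylamino gives a 3.8-fold lower number from compound 3 to compound 4 (0.58 log units; beyond the scatter), so with 4-chloro-2-methylphenyl on the amide-type nitrogen this change clears the scatter, which it did not do in the pair compound 1 and compound 2, although the two steps cannot be told apart from each other: the same change on two cores in this assay, a 1.5-fold higher number (0.18 log units; within the scatter) from compound 1 to compound 2 and a 3.8-fold higher number (0.58 log units; beyond the scatter) from compound 4 to compound 3, 2.5-fold (0.40 log units) apart, within the scatter of two such steps The exchange on the amide-type nitrogen, read with cyclopropylamino in place, gives a 1.6-fold lower number from compound 1 to compound 4 (0.20 log units; within the scatter), and its apparent change of direction between the two cores is no firm reversal: the same change on two cores in this assay, a 1.6-fold higher number (0.20 log units; within the scatter) from compound 2 to compound 3 and a 1.6-fold lower number (0.20 log units; within the scatter) from compound 1 to compound 4, 2.5-fold (0.40 log units) apart, within the scatter of two such steps Among these four compounds, an advantage for cyclopropylamino over anilino rests on the pair compound 3 and compound 4 alone, and the pair compound 1 and compound 2 goes against calling it general.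

The compounds shown leave open whether another group on that nitrogen, such as methyl, a longer chain like n-propyl or a chain ending in an amine, would follow cyclopropyl. They also leave open how the chlorine and the methyl of 4-chloro-2-methylphenyl each contribute, as the two appear only together.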